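Halogen variation on the isopropoxy-bearing ring of compound 2

The source may report more compounds than this note shows. Statements on the series, on what has been measured and on what is new or still open speak of the compounds shown alone.

Compound 1 `Cc1cc(CCC(=O)O)ccc1-c1noc(-c2ccc(OC(C)C)c(F)c2)n1`: > 10000 nM
Compound 2 `Cc1cc(CCC(=O)O)ccc1-c1noc(-c2ccc(OC(C)C)c(Cl)c2)n1`: > 10000 nM

In a functional assay on CHO cells with sphingosine 1-phosphate receptor 4 (Homo sapiens) as the target, read by GTPgammaS binding (on this read-out lower numbers stand for an effect already at smaller amounts and higher numbers for an effect only at larger amounts of compound), compound 1 gives > 10000 nM, a limit of the assay. In this assay compound 2 gives > 10000 nM, likewise a limit. The step that the two limits leave unreadable from compound 1 to compound 2 is therefore unreadable, as the limit of > 10000 nM in this assay, at which 2 of the 2 values shown sit, records. Compound 3 `Cc1cc(CCC(=O)O)ccc1-c1noc(-c2ccc(OC(C)C)c(Br)c2)n1` carries the change (bromo in place of chloro on an aromatic carbon). Among the compounds with values here, since the only measured halogen step sits at the limit, no direction can be read from it. Compound 3 is expected to remain at or around the limit, the step that the limit leaves unreadable from compound 2 to compound 3 being an estimate only. The estimated value for compound 3 is 15000 nM, within 4000 nM to 50000 nM.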

Compound 3, half-maximal effective concentration: > 10000 nM
Compound 3 ended at the assay's limit (the forecaster's own chance of this, stated with the estimate: 80%); the middle value does not contradict the limit.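

No step can be read among compound 1, compound 2 and compound 3, as all three sit at the same limit: the limit of > 10000 nM in this assay, at which 3 of the 3 values shown sit. From the compounds shown here alone, how the fluoro, chloro and bromo groups rank in this assay remains open.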